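The source may report more compounds than this note shows. Statements on the series, on what has been measured and on what is new or still open speak of the compounds shown alone.

Compound 1, with the structure `O=C1C(N2CCCCC2)=CC(=O)c2c1nc1n2[C@H]2OC[C@@H](O)[C@H]2OC1`, carries a piperidin-1-yl group on its shared core. In a functional assay on HeLa cells (Homo sapiens) for inhibition, read by sulforhodamine B assay (on this read-out lower numbers stand for stronger inhibition and higher numbers for weaker inhibition), compound 1 gives > 16000 nM, and this figure is a limit of the assay rather than a measured number. Where compound 1 stands is therefore told only by the limit of > 16000 nM in this assay, at which 1 of the 2 values shown sits. A second member of the series, compound 2 with the structure `O=C1C=C(Nc2ccccc2)C(=O)c2c1nc1n2[C@H]2OC[C@@H](O)[C@H]2OC1`, gives 5620 nM in this assay, so for this core a number within the measured range has been reached.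

The compound that has not yet been measured is compound 3, with the structure `O=C1C(NC2CCCCC2)=CC(=O)c2c1nc1n2[C@H]2OC[C@@H](O)[C@H]2OC1`. Its difference from compound 1 is cyclohexylamino in place of piperidin-1-yl on a double-bonded ring carbon. For the measured compounds named here, no step between two measured compounds of this kind is known. The direction of this change can therefore only be expected, not read off. The expected step out of the limit of compound 1 is an at least 2.0-fold lower number from compound 1 to compound 3 (0.30 log units; that floor lies within the scatter). For compound 3 the estimate in this assay is 8000 nM, expected to fall between 2500 nM and 25000 nM.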

Compound 3, half-maximal inhibitory concentration: > 16000 nM
Compound 3: a limit, no number; the forecaster's own chance of this, stated with the estimate: 35%; middle value at least 2.0-fold (0.30 log units) away from the limit.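

For the compounds shown here, compound 1 and compound 3 each give only a limit of the assay, not a number, so no step between them can be read: the limit of > 16000 nM in this assay, at which 2 of the 3 values shown sit. The compounds shown leave open how strongly compound 1 and compound 3 inhibit in this assay, and whether cyclohexylamino in place of piperidin-1-yl changes that at all.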